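Swapping azepan-1-yl for 4-chloropiperidin-1-yl in compound 2

The source may hold more compounds than are shown below. What is called first, only, known or untested is meant among the compounds shown, and "the series" means these compounds.

Measured so far in an ADME assay (liver, Mus musculus) for metabolic stability, using microsomes; a higher number here means that the compound lasts longer, a lower number that the compound disappears faster:
- Compound 1 `CCc1nc2cc(Cl)ccn2c1C(=O)NCc1ccc(-c2ccc[nH]2)cc1`: 0.18 h
- Compound 2 `CCc1nc2cc(Cl)ccn2c1C(=O)NCc1ccc(N2CCCCCC2)cc1`: 0.0317 h

Of these two numbers, the lower belongs to compound 2, at 0.0317 h. It therefore disappears faster than compound 1. The next molecule, compound 3 `CCc1nc2cc(Cl)ccn2c1C(=O)NCc1ccc(N2CCC(Cl)CC2)cc1`, has not been measured yet. It differs from compound 2 in one place, on an aromatic carbon: 4-chloropiperidin-1-yl in place of azepan-1-yl on an aromatic carbon. For the measured compounds named here, only one measured step bears on this change, made on that same aromatic carbon, and it is a modest one. Here one non-aromatic ring replaces another, so a smaller step than a 5.7-fold lower number from compound 1 to compound 2 (0.75 log units; beyond the scatter) is expected, perhaps none beyond the scatter, leaning slightly upward in this assay. The estimated step is a 1.6-fold higher number from compound 2 to compound 3 (0.20 log units; within the scatter). For compound 3 the expected half-life is 0.05 h, with an estimated range from 0.02 h to 0.13 h.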

Compound 3, half-life: 0.0867 h
The estimate for compound 3 lay 1.7-fold (0.24 log units) below the measured number; the measured number falls inside the stated range.
By their numbers in this assay, from the lowest: compound 2; then compound 3; then compound 1.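

In this assay the exchange of one non-aromatic ring for another on this aromatic carbon is not a neutral swap: 4-chloropiperidin-1-yl in place of azepan-1-yl gives a 2.7-fold higher number from compound 2 to compound 3 (0.44 log units; beyond the scatter) even though the two groups have the same number of heavy atoms. The gain is only partial, since replacing 1H-pyrrol-2-yl with 4-chloropiperidin-1-yl still gives a 2.1-fold lower number from compound 1 to compound 3 (0.32 log units; beyond the scatter) and leaves compound 3 between the other two. No measurement available here explains why these groups differ.

This single change both shrinks the ring from seven members to six and adds chlorine, so the compounds shown cannot separate those two differences. A plain piperidin-1-yl group would divide them, while a morpholin-4-yl ring on the same carbon remains an open comparison.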